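Bromophenoxy Position Swap on a Thia Core Diaminotriazine

The source may hold more compounds than are shown below. What is called first, only, known or untested is meant among the compounds shown, and "the series" means these compounds.

Measured compounds:
Compound 1 `CC(C)(C)c1ccc(OCCCON2C(N)=NC(N)=NC23CCSCC3)cc1`: 86.6%
Compound 2 `NC1=NC2(CCSCC2)N(OCCCOc2ccc(Br)cc2)C(N)=N1`: "not determined" (no result reported)
Compound 3 `NC1=NC2(CCOCC2)N(OCCCOc2ccc(Cl)c(Cl)c2)C(N)=N1`: "not determined" (no result reported)

In an assay on isolated protein for inhibition of Dihydrofolate reductase (Homo sapiens), read by spectrophotometry, using NADPH, with stated times of 5 s and 6 min, tested at 50 uM (a higher number here means a stronger effect of the compound at the concentration tested, a lower number a weaker effect), compound 1 gives 86.6%. Compound 2 has no single number in this assay, and compound 3 likewise gives "not determined" (no result reported), so compound 2 stands without a measured value and without a step to any other compound.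

Compound 4 `NC1=NC2(CCSCC2)N(OCCCOc2ccccc2Br)C(N)=N1` is to be measured in this assay. It differs from compound 2 by 2-bromophenyl in place of 4-bromophenyl on an oxygen on a saturated carbon. With no number for compound 2, the size and direction of the step from compound 2 to compound 4 in this assay cannot be drawn from the data; the expectation rests on compound 1, which shares the same core and gives 86.6%. Compound 4 is expected to give about 72%, with a range of 40% to 95%.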

Compound 4, a percentage reported as inhibition, at one concentration (the size of the read-out at that concentration, not a potency): 89.6%
Compound 4: middle estimate off by 17.6 percentage points, on the low side; low and high end bracket the measured number.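

Going by these compounds alone, no step from compound 2 to compound 4 can be read in this assay, as compound 2 has no single number there. The compounds shown leave open whether 2-bromophenyl in place of 4-bromophenyl changes the read-out. Nothing given bears on the result.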